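A tert-butylamino swap on a carbonyl carbon

This account rests on a few compounds, and the source may have more. Where it says the series, first, only, none or still open, it means among the compounds named here.

Values in a functional assay on HepG2 cells (Homo sapiens) for inhibition, read by scintillation counting, with a stated time of 2 h (a higher number here means a weaker inhibitor, a lower number a stronger inhibitor), are as follows
compound 1 `CCNC(=O)Nc1sc2ccccc2c1C(=O)N1CCN(C2CCN(C(C)=O)CC2)CC1` – "not determined" (no result reported)
compound 2 `CCNC(=O)Nc1sc2ccccc2c1C(=O)N1CCN(C2CCN(C(=O)C3CCCCC3)CC2)CC1` – 146 nM
compound 3 `CCNC(=O)Nc1sc2ccccc2c1C(=O)N1CCN(C2CCN(C(=O)OC(C)C)CC2)CC1` – 208 nM

Among the compounds with values here, only two compounds have a number so far, because compound 1 has no reported result. In this assay compound 3 gives 208 nM and cannot be told apart from compound 2, which gives 146 nM.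

The next compound is compound 4 `CCNC(=O)Nc1sc2ccccc2c1C(=O)N1CCN(C2CCN(C(=O)NC(C)(C)C)CC2)CC1`. Within the data shown here, it carries (tert-butyl)amino in place of isopropoxy on a carbonyl carbon, the one whose other neighbour is an amide-type nitrogen in a ring. The counted difference is (tert-butyl)amino in place of isopropoxy on a carbonyl carbon.

Among the measured compounds shown here, only one measured step bears on this change. It sits on the same carbonyl carbon, with isopropoxy in place of cyclohexyl, and it is a 1.4-fold higher number from compound 2 to compound 3 (0.15 log units; within the scatter). Exchanging the group at this place has therefore not yet moved the number beyond the scatter. For the measured compounds named here, that is thin evidence, since it is a single step and no measured compound carries (tert-butyl)amino.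

No clear change is therefore expected in this assay, and no direction can be favoured. The expected size of the change is a 1.2-fold lower number from compound 3 to compound 4 (0.09 log units; within the scatter). For compound 4 the estimated value is 170 nM, with an expected range from 60 nM to 480 nM.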

Compound 4, half-maximal inhibitory concentration: 775 nM
Beside the measured number, compound 4's estimate is 4.6-fold (0.66 log units) below it; measured number outside the range, above it.
By their numbers in this assay, from the lowest: compounds 2 and 3 (each within the scatter of the next); then compound 4.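

In this assay the group on this carbonyl carbon turns out to matter: putting (tert-butyl)amino in place of isopropoxy gives a 3.7-fold higher number from compound 3 to compound 4 (0.57 log units; beyond the scatter) and so clears the scatter, which the earlier exchange of cyclohexyl for isopropoxy did not do (a 1.4-fold higher number from compound 2 to compound 3 (0.15 log units; within the scatter)). Measured against cyclohexyl, the same group gives a 5.3-fold higher number from compound 2 to compound 4 (0.72 log units; beyond the scatter) and so makes compound 4 the weakest inhibitor of the three compounds with a number, which means that this position does not accept every group equally. Nothing available here explains why the number rises with this change.

Compound 1 gives "not determined" (no result reported) and so steps to it cannot be read. On these data alone, the swap changes two things at once, an oxygen link becoming a nitrogen link that carries a hydrogen-bond donor and isopropyl becoming tert-butyl, so it remains open which of the two goes with the higher number, and a tert-butoxy or an isopropylamino group on the same carbonyl carbon would separate them.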